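Thiazolylsulfanyl chain replaces cyclohexyl on the ring nitrogen

This account rests on a few compounds, and the source may have more. Where it says the series, first, only, none or still open, it means among the compounds named here.

Three compounds share one core and differ only in the group on a saturated chain carbon bound to an aromatic nitrogen. In a functional assay (trachea) with Cavia porcellus as the target (a lower number here means a stronger inhibitor, a higher number a weaker inhibitor), compound 1 `CCCCCCCCn1nc(-c2cccnc2)c2ccccc2c1=O` gives 21900 nM, compound 2 `C=CCn1nc(-c2cccnc2)c2ccccc2c1=O` gives 2140 nM, and compound 3 `O=c1c2ccccc2c(-c2cccnc2)nn1CC1CCCCC1` gives 209 nM, the strongest of the three. The steps of a 100-fold lower number from compound 1 to compound 3 (2.02 log units; beyond the scatter) and a 10-fold lower number from compound 2 to compound 3 (1.01 log units; beyond the scatter) both favour cyclohexyl, and the step of a 10-fold lower number from compound 1 to compound 2 (1.01 log units; beyond the scatter) places vinyl ahead of heptyl. Compound 4 `O=c1c2ccccc2c(-c2cccnc2)nn1CCSc1nccs1` carries ((1,3-thiazol-2-yl)sulfanyl)methyl in place of cyclohexyl on a saturated chain carbon bound to an aromatic nitrogen. For the measured compounds named here, no measured step covers a heteroaromatic sulfanyl chain, and every departure from cyclohexyl seen here gave a higher number. A moderately higher number is therefore expected for compound 4, a 2.9-fold higher number from compound 3 to compound 4 (0.46 log units; beyond the scatter). Compound 4 is estimated at 600 nM, within 150 nM to 3000 nM.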

Compound 4, half-maximal inhibitory concentration: 10500 nM
For compound 4 the middle estimate is 18-fold (1.24 log units) below the measured one; measured number above the stated range.
By their numbers in this assay, from the lowest: compound 3; then compound 2; then compound 4; then compound 1.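

In this assay the move from cyclohexyl to ((1,3-thiazol-2-yl)sulfanyl)methyl is far from mild: a 50-fold higher number from compound 3 to compound 4 (1.70 log units; beyond the scatter) is the result at this position. Compound 4 also trails the allyl-bearing compound, with a 4.9-fold higher number from compound 2 to compound 4 (0.69 log units; beyond the scatter) on that comparison, and it sits only slightly ahead of the octyl-bearing compound, with a 2.1-fold lower number from compound 1 to compound 4 (0.32 log units; beyond the scatter) as the step. A ring at the end of this chain therefore does not by itself preserve the low number of compound 3.

As far as these compounds go, whether the sulfur or the thiazole ring accounts for the loss stays open, as does how a phenyl or morpholine group would read here. No available evidence explains the size of this step.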